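Swapping a para methoxy for chloro on the anilide

This account rests on a few compounds, and the source may have more. Where it says the series, first, only, none or still open, it means among the compounds named here.

Two members of a series built on a shared core have been tested in a functional assay on cells (Leukemia cell, Homo sapiens) for cytotoxicity; a higher number here means a weaker inhibitor of growth, a lower number a stronger inhibitor of growth. Compound 1 `O=C(/C=C/C(=O)N1C/C(=C\c2ccccc2)C(=O)/C(=C/c2ccccc2)C1)Nc1ccc(Cl)c(Cl)c1` carries a 3,4-dichlorophenyl on its amide-type nitrogen and gives 447 nM in this assay. Compound 2 `COc1ccc(NC(=O)/C=C/C(=O)N2C/C(=C\c3ccccc3)C(=O)/C(=C/c3ccccc3)C2)cc1` carries a 4-methoxyphenyl instead and gives 105 nM in this assay, the lower of the two numbers: the step of a 4.3-fold lower number from compound 1 to compound 2 (0.63 log units; beyond the scatter) lies beyond the scatter, so compound 2 is the stronger of the two measured compounds.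

Compound 3 `O=C(/C=C/C(=O)N1C/C(=C\c2ccccc2)C(=O)/C(=C/c2ccccc2)C1)Nc1ccc(Cl)cc1` differs from compound 2 in one place, (chloro in place of methoxy on an aromatic carbon). Within the data shown here, only the step from compound 1 to compound 2 bears on this change, and it does so only in part: it removed two chlorines and added a methoxy at once, whereas compound 3 removes the methoxy and adds a single chloro. Because a 4.3-fold lower number from compound 1 to compound 2 (0.63 log units; beyond the scatter) favoured the methoxy compound, compound 3 is expected to land between the two measured numbers, a modest rise expected in this assay as a 1.9-fold higher number from compound 2 to compound 3 (0.28 log units; within the scatter). Compound 3 is therefore estimated at 200 nM, with a range from 90 nM to 500 nM.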

Compound 3, concentration for 50% growth inhibition: 589 nM
Beside the measured number, compound 3's estimate is 2.9-fold (0.47 log units) below it; the whole stated range lies below it.
By their numbers in this assay, from the lowest: compound 2; then compounds 1 and 3 (each within the scatter of the next).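

In this assay, exchanging the methoxy for a chloro on the aromatic ring, with nothing else altered, gives a 5.6-fold higher number from compound 2 to compound 3 (0.75 log units; beyond the scatter) and so isolates a change that the earlier comparison had mixed with the loss of a second chlorine. Going from the 3,4-dichlorophenyl to the 4-chlorophenyl gives a 1.3-fold higher number from compound 1 to compound 3 (0.12 log units; within the scatter) and so leaves the two chlorinated compounds indistinguishable in this test, which points to the methoxy group, rather than the number of chlorines, as what sets compound 2 apart from both. Nothing measured here explains why the 4-methoxyphenyl compound gives the lower number.

As far as these compounds go, whether this gain is particular to methoxy remains open, since a hydroxy, an amine, a methyl or an ethoxy at this place on the ring, or a plain phenyl with only hydrogen there, could show whether other groups share it. It is also unknown whether the same exchange would give a step of similar size on a different core, because these three compounds share a single one.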